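Fluorophenyl for carboxyphenyl on the amine nitrogen

The compounds below may be only part of what the source reports. "The series", "measured", "known", "first", "only" and "open" are said of these compounds alone.

Measured compounds:
compound 1, `C=C1[C@@H](OC(C)=O)C[C@@H]2[C@](C)(COC=O)[C@H](OC(C)=O)CC[C@@]2(C)[C@@H]1C[C@@H](Nc1ccccc1C(=O)O)C1=CCOC1=O`: 28700 nM
compound 2, `C=C1[C@@H](OC(C)=O)C[C@@H]2[C@](C)(CO[Si](C)(C)C(C)(C)C)[C@H](OC(C)=O)CC[C@@]2(C)[C@@H]1C[C@@H](Nc1ccc(C(=O)O)cc1)C1=CCOC1=O`: 4630 nM
compound 3, `C=C1[C@@H](OC(C)=O)C[C@@H]2[C@](C)(CO[Si](C)(C)C(C)(C)C)[C@H](OC(C)=O)CC[C@@]2(C)[C@@H]1C[C@@H](Nc1cccc2ccccc12)C1=CCOC1=O`: 15000 nM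

In a functional assay on HT-29 cells (Homo sapiens) for cytotoxicity, read by sulforhodamine B assay (a higher number here means a weaker inhibitor, a lower number a stronger inhibitor), compound 1 gives 28700 nM, the highest of the three numbers; compound 3 sits within the scatter of it, while compound 2 lies beyond it. Compound 4, `C=C1[C@@H](OC(C)=O)C[C@@H]2[C@](C)(COC=O)[C@H](OC(C)=O)CC[C@@]2(C)[C@@H]1C[C@@H](Nc1cccc(F)c1)C1=CCOC1=O`, differs from compound 1 by 3-fluorophenyl in place of 2-carboxyphenyl on an amine nitrogen. Going by the values given here, the only measured step bearing on this is a 3.2-fold higher number from compound 2 to compound 3 (0.51 log units; beyond the scatter), where a carboxyphenyl on the amine nitrogen likewise gave way to an aryl group lacking that substituent, though on a core that differs from compound 1 elsewhere. A modest rise, a 1.4-fold higher number from compound 1 to compound 4 (0.14 log units; within the scatter), is therefore expected. Compound 4 is estimated at 40000 nM, within 13000 nM to 120000 nM.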

Compound 4, half-maximal inhibitory concentration: 9410 nM
For compound 4 the middle estimate is 4.3-fold (0.63 log units) above the measured one, and the stated range ends above it.
By their numbers in this assay, from the lowest: compound 2; then compounds 4, 3 and 1 (each within the scatter of the next, the first and the last beyond it).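

In this assay, the step to 3-fluorophenyl gave a 3.0-fold lower number from compound 1 to compound 4 (0.48 log units; beyond the scatter), so on the core of compound 1 a carboxyphenyl group on the amine nitrogen is not needed for the lower number. This runs opposite to a 3.2-fold higher number from compound 2 to compound 3 (0.51 log units; beyond the scatter), so the two replacements of a carboxyphenyl group shown here share no single direction. Nothing available here accounts for the change.

The step swaps the carboxylic acid for fluorine and moves the substituent at once, leaving their contributions unseparated. A plain phenyl group or a methoxyphenyl group on this nitrogen could help separate them.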